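Swapping an aryl for a nonyl chain on the hydrazide

The source may report more compounds than this note shows. Statements on the series, on what has been measured and on what is new or still open speak of the compounds shown alone.

Among the measured compounds shown here, compound 2 `Cc1cc(C)cc(C(=O)N(NC(=O)c2ccc(Cl)cc2)C(C)(C)C)c1` holds the lowest of the two numbers so far in an assay on cells for agonist activity at ecdysone receptor (Bombyx mori), read by a luciferase reporter, with a stated time of 24 h; a lower number here means that less compound is needed, a higher number that more compound is needed for the effect: compound 2 gives 19.1 nM, while compound 1 `CC(C)(C)N(NC(=O)c1ccc(Cl)cc1)C(=O)c1ccccc1Cl` gives 115 nM. For the measured compounds named here, the one step between them, a 6.0-fold lower number from compound 1 to compound 2 (0.78 log units; beyond the scatter), concerns the other carbonyl carbon of the shared core. Compound 3 `CCCCCCCCCC(=O)NN(C(=O)c1cc(C)cc(C)c1)C(C)(C)C` differs from compound 2 at the remaining acyl group: nonyl in place of 4-chlorophenyl on a carbonyl carbon. Going by the values given here, no measured step touches this carbonyl carbon, and none exchanges a ring for a chain, so the step from compound 1 to compound 2 informs only loosely; it shows that this core tolerates a change of aryl group on one side with a modest shift, but says nothing about losing the ring altogether. Compound 3 is therefore expected to need more compound than compound 2 in this assay, with a 79-fold higher number from compound 2 to compound 3 (1.90 log units; beyond the scatter) as the estimated step and wide uncertainty. The estimate for compound 3 is 1500 nM, within a range from 200 nM to 12000 nM.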

Compound 3, half-maximal effective concentration: 1550 nM
Compound 3: middle estimate off by 1.0-fold (0.01 log units), on the low side, within the range that was stated.
By their numbers in this assay, from the lowest: compound 2; then compound 1; then compound 3.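

At this carbonyl carbon, replacing 4-chlorophenyl with nonyl in this assay gives an 81-fold higher number from compound 2 to compound 3 (1.91 log units; beyond the scatter), the first measured view of what this position does when a ring gives way to an open chain. This is a larger step than a 6.0-fold lower number from compound 1 to compound 2 (0.78 log units; beyond the scatter), which came from a change of aryl group on the other carbonyl carbon, yet the loss of the ring does not end the response, since compound 3 still gives a measurable number of 1550 nM. Nothing available here bears on why the change has this effect, so the result stands as an observation about these two compounds only.

The compounds shown leave open whether the size of the step comes with the loss of the ring itself or is tied to this particular chain, as a shorter butyl chain or a longer dodecyl chain at the same carbonyl carbon would show. They also leave open how an unsubstituted phenyl, or a chain ending in an amine or a carboxylic acid, would compare with 4-chlorophenyl and nonyl at this place.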